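Acetoxy in Place of Benzamido on the Saturated Ring

The source may hold more compounds than are shown below. What is called first, only, known or untested is meant among the compounds shown, and "the series" means these compounds.

Compound 2 `O=C(NC1CCC(CN2CCN(c3cc(=O)c4cc(C(F)(F)F)cc([N+](=O)[O-])c4s3)CC2)CC1)c1ccccc1` has been tested in an ADME assay on cells (Hepatocyte, Homo sapiens) for metabolic stability; a higher number here means that the compound lasts longer, a lower number that the compound disappears faster. In this assay compound 2 gives > 1.55 h, which is a limit of the assay rather than a number. Compound 1 `CS(=O)(=O)NC1CCC(CN2CCN(c3cc(=O)c4cc(C(F)(F)F)cc([N+](=O)[O-])c4s3)CC2)CC1` shares the same core, with a methylsulfonyl where compound 2 carries a benzoyl on an amine nitrogen. In this assay compound 1 gives > 1.55 h, again a limit. The step that the two limits leave unreadable from compound 1 to compound 2 cannot be sized because of the limit of > 1.55 h in this assay, at which 2 of the 2 values shown sit.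

Compound 3 `CC(=O)OC1CCC(CN2CCN(c3cc(=O)c4cc(C(F)(F)F)cc([N+](=O)[O-])c4s3)CC2)CC1` differs from compound 2 in acetoxy in place of benzamido on a saturated ring carbon. Going by the values given here, the only measured step touches a different part of the structure and is itself unreadable, so no measured step tells how this change will move the half-life. The step of an at least 1.2-fold lower number from compound 2 to compound 3 (0.11 log units; that floor lies within the scatter) is therefore an estimate with wide uncertainty. Compound 3 is expected to give about 1.2 h, with a range from 0.4 h to 3 h.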

Compound 3, half-life: < 0.15 h
Compound 3: only a limit was reported (the forecaster's own chance of this, stated with the estimate: 35%); at least 8.0-fold (0.90 log units) between middle value and limit.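

In this assay, going by these compounds alone, the earlier compounds showed only that two groups on this saturated ring carbon, benzamido and methanesulfonamido, sit at the same limit, so the position itself could not be judged. Now it is clear that this position can move the half-life a long way: acetoxy in place of benzamido gives an at least 10-fold lower number from compound 2 to compound 3 (1.01 log units; beyond the scatter), and acetoxy in place of methanesulfonamido gives an at least 10-fold lower number from compound 1 to compound 3 (1.01 log units; beyond the scatter). Both steps are only minimum sizes, because compound 3 sits at a limit of its own, as compounds 1 and 2 do at theirs: the limit of < 0.15 h in this assay, at which 1 of the 3 values shown sits.

The compounds shown leave open whether the drop comes with the acetoxy group itself or with the loss of the nitrogen-linked groups. An acetamido or a hydroxyl group on the same ring carbon would help separate these two readings.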